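This account rests on a few compounds, and the source may have more. Where it says the series, first, only, none or still open, it means among the compounds named here.

Measured in a functional assay on NCI-H1975 cells (Homo sapiens) for inhibition, read by MTT assay, with a stated time of 72 h; on this read-out higher numbers stand for weaker inhibition and lower numbers for stronger inhibition:
- Compound 1 `CCN1CCN(c2cc(C(F)(F)F)nc(SCc3ccc(C(F)(F)F)cc3)n2)CC1`: 15000 nM
- Compound 2 `FC(F)(F)c1ccc(CSc2nc(N3CCN(c4ccccc4)CC3)cc(C(F)(F)F)n2)cc1`: > 50000 nM, a limit
- Compound 3 `CC(C)(C)OC(=O)N1CCN(c2cc(C(F)(F)F)nc(SCc3ccc(C(F)(F)F)cc3)n2)CC1`: > 50000 nM, a limit

Compound 1 alone gives a number, and its steps to both others are beyond the scatter. Compound 2 and compound 3 give no number: theirs is the limit of > 50000 nM in this assay, at which 2 of the 3 values shown sit.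

Compound 4 `FC(F)(F)c1ccc(CSc2nc(Sc3nncs3)cc(C(F)(F)F)n2)cc1` has not been measured. It carries (1,3,4-thiadiazol-2-yl)sulfanyl in place of 4-ethylpiperazin-1-yl on an aromatic carbon.

Two readable steps bear on this, though both replace only the ethyl on an amine nitrogen in a ring. With phenyl there is an at least 3.3-fold higher number from compound 1 to compound 2 (0.52 log units; beyond the scatter), and with tert-butoxycarbonyl there is an at least 3.3-fold higher number from compound 1 to compound 3 (0.52 log units; beyond the scatter). The remaining comparison is a step that the two limits leave unreadable from compound 2 to compound 3. Compound 4 replaces the whole 4-ethylpiperazin-1-yl, so these steps guide the expectation only loosely. Both start at compound 1 with 15000 nM, and both lead upward, so a higher number is expected in this assay. The expected step is a 2.3-fold higher number from compound 1 to compound 4 (0.37 log units; beyond the scatter). Compound 4 is estimated at 35000 nM, with an expected range from 12000 nM to 100000 nM.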

Compound 4, half-maximal inhibitory concentration: 2270 nM
For compound 4 the middle estimate is 15-fold (1.19 log units) above the measured one; the measured number lies below the stated range.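

Replacing the whole 4-ethylpiperazin-1-yl on this aromatic carbon with (1,3,4-thiadiazol-2-yl)sulfanyl gives a 6.6-fold lower number from compound 1 to compound 4 (0.82 log units; beyond the scatter) in this assay, so this position tolerates a group without the piperazine, and the read-out moves toward stronger inhibition. The earlier steps shown here changed only the group on the amine nitrogen and moved only upward, and that direction does not carry over to replacing the whole group. Compound 2 and compound 3 each remain a limit and not a number: the limit of > 50000 nM in this assay, at which 2 of the 4 values shown sit.

The compounds shown do not separate the share of the sulfanyl link from that of the 1,3,4-thiadiazole ring, which a phenylsulfanyl group or a thiadiazole joined through an amine nitrogen could address. As far as these compounds go, it also stays open whether a different five-membered ring, such as a 1,2,4-triazole, would read the same at this position.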